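The compounds below may be only part of what the source reports. "The series", "measured", "known", "first", "only" and "open" are said of these compounds alone.

Measured in an ADME assay on BHK-21 cells (Mesocricetus auratus) for cytotoxicity, read by MTT assay; a higher number here means that more compound is tolerated, a lower number that less compound is tolerated:
Compound 1 `COc1ccc(-c2nc3cc(/C(C)=N/NC(N)=O)ccc3[nH]2)c(OC)c1`: >= 100000 nM (a limit)
Compound 2 `COc1ccc(-c2nc3cc(C(C)=O)ccc3n2C2CCCCC2)c(OC)c1`: 8500 nM
Compound 3 `C/C(=N\NC(N)=O)c1ccc2c(c1)nc(-c1ccc(Cl)cc1)n2C1CCCCC1`: > 100000 nM (a limit)

Compound 3 has no exact number in this assay. Its result is the limit of > 100000 nM in this assay, at which 1 of the 3 values shown sits. Compound 1 is likewise known only as a limit, which leaves compound 2 as the only one of the three with a measured number.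

The next compound, compound 4 `COc1ccc(-c2nc3cc(/C(C)=N/NC(N)=O)ccc3n2C2CCCCC2)c(OC)c1`, has 2,4-dimethoxyphenyl in place of 4-chlorophenyl on an aromatic carbon, and the change is counted as 2,4-dimethoxyphenyl in place of 4-chlorophenyl on an aromatic carbon. The swap sits on an aromatic carbon of a five-membered aromatic ring with 2 nitrogen, next to the ring atom that bears a cyclohexyl group.

Going by the values given here, no measured step shows what this swap does, so any expectation rests on the values alone. The entering group also stands on compound 1, whose >= 100000 nM is a limit. It stands on compound 2 as well, where compound 2 gives 8500 nM, so a real number cannot be ruled out. The expected change is modest, with a slight downward lean: an at least 1.2-fold lower number from compound 3 to compound 4 (0.09 log units; that floor lies within the scatter). For compound 4 the estimated value is 80000 nM, with an expected range from 25000 nM to 150000 nM.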

Compound 4, half-maximal cytotoxic concentration: 19000 nM
Beside the measured number, compound 4's estimate is 4.2-fold (0.62 log units) above it, and the stated range ends above it.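

In this assay, 2,4-dimethoxyphenyl in place of 4-chlorophenyl at this position gives an at least 5.2-fold lower number from compound 3 to compound 4 (0.72 log units; beyond the scatter), the first sign that the group here can move the number; the size is only a floor, as the result for compound 3 is a limit: the limit of > 100000 nM in this assay, at which 1 of the 4 values shown sits.

With 2,4-dimethoxyphenyl kept, cyclohexyl in place of hydrogen on the aromatic nitrogen gives an at least 5.2-fold lower number from compound 1 to compound 4 (0.72 log units; beyond the scatter), again a floor, as the result for compound 1 is a limit: the limit of >= 100000 nM in this assay, at which 1 of the 4 values shown sits.

With both of those groups kept, the group of 7 heavy atoms in place of the group of 3 heavy atoms on the aromatic carbon gives a 2.2-fold higher number from compound 2 to compound 4 (0.35 log units; beyond the scatter).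

The compounds shown leave open whether the lower number in compound 4 goes with the two methoxy groups together or with one of them, which a 4-methoxyphenyl or an unsubstituted phenyl at this position would separate. They also leave open whether a methyl on the aromatic nitrogen would do the same as cyclohexyl.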